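A few compounds are considered here, and "the series" means these few. Any claim that something is new, unique, unknown or untested is made for them only; others in the source may bear on it.

Measured compounds:
Compound 1 `COC(=O)C1=C(C)NC(=O)NC1c1ccc(O)cc1` — 17200 nM
Compound 2 `COC(=O)C1=C(C)NC(=O)NC1c1ccc([N+](=O)[O-])cc1` — 49100 nM

Among the measured compounds shown here, in an assay for inhibition of beta-glucuronidase (Bos taurus), read by spectrophotometry, with a stated time of 30 min (on this read-out higher numbers stand for weaker inhibition and lower numbers for stronger inhibition), compound 2 holds the highest of the two numbers measured; the only neighbour is compound 1, which sits a 2.9-fold higher number from compound 1 to compound 2 (0.46 log units; beyond the scatter) away. That single step swapped hydroxy for nitro on the aromatic carbon and pushed the number up by a modest but real amount.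

Compound 3 `COC(=O)C1=C(C)NC(=O)NC1c1ccc(C(C)C)cc1` has not been measured. It differs from compound 2 in one place: isopropyl in place of nitro on an aromatic carbon. For the measured compounds named here, the one measured step, a 2.9-fold higher number from compound 1 to compound 2 (0.46 log units; beyond the scatter), is the only evidence that a change at this aromatic carbon moves the number at all, and it says that leaving the hydroxy behind made the inhibition weaker. Isopropyl, however, appears in no measured pair, so nothing shows in which direction removing the nitro in favour of isopropyl will turn out. The change may simply undo part of the rise seen in compound 2, or it may leave the number where it is.

Compound 3 is therefore expected to give 30000 nM, within a range of 10000 nM to 90000 nM. This estimate corresponds to an expected 1.6-fold lower number from compound 2 to compound 3 (0.21 log units; within the scatter).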

Compound 3, half-maximal inhibitory concentration: "not active" (no number reported)
Compound 3 has no reported number here; the estimate stays without a comparison.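

In this assay compound 3 is reported only as "not active", without a number, so no new step can be read between compound 2 and compound 3. Nothing available accounts for this result. The compounds shown leave open how far isopropyl in place of nitro on the aromatic carbon moves the number.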